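Swapping Ethyl for Hydroxy on a Sulfonyl Chain

The compounds below may be only part of what the source reports. "The series", "measured", "known", "first", "only" and "open" are said of these compounds alone.

Of the compounds shown here, three sharing one core have been measured in a functional assay, read by fluorescence and spectrophotometry, with a stated time of 1 h (a lower number here means that less compound is needed, a higher number that more compound is needed for the effect), so far. Compound 1 (`CCCCCCCCCCCCS(=O)(=O)/C=C/c1ccc(O)c(O)c1`) gives 8500 nM in this test, compound 2 (`C=CCCCCCCCS(=O)(=O)/C=C/c1ccc(O)c(O)c1`) gives 6900 nM and compound 3 (`CCCCCCCCCCCS(=O)(=O)/C=C/c1ccc(O)c(O)c1`) gives 11400 nM on the same scale. Compound 3 does not separate from either of the others, with steps of a 1.3-fold higher number from compound 1 to compound 3 (0.13 log units; within the scatter) and a 1.7-fold higher number from compound 2 to compound 3 (0.22 log units; within the scatter) leading to it.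

Compound 4 (`O=S(=O)(/C=C/c1ccc(O)c(O)c1)CCCCCCCCCO`) departs from compound 3 by one change (hydroxy in place of ethyl on a saturated chain carbon, nine bonds along the chain from a sulfonyl sulfur), namely hydroxy in place of ethyl on a saturated chain carbon, nine bonds along the chain from a sulfonyl sulfur. The closest evidence comes from the three chain changes already measured, which include a 1.2-fold lower number from compound 1 to compound 2 (0.09 log units; within the scatter) as well as the two steps above. All three stay within the scatter, but none of them brings a hydroxy group into the chain, so the evidence is indirect and the range must stay wide.

The expected change is a 1.1-fold lower number from compound 3 to compound 4 (0.06 log units; within the scatter) and no clear shift in either direction is anticipated. For compound 4 the estimated value is 10000 nM with an expected range from 3500 nM to 30000 nM in this assay when it is measured.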

Compound 4, half-maximal effective concentration: 7500 nM
Estimate against measurement, compound 4: 1.3-fold (0.12 log units) above, and the stated range covers the measured number.
By their numbers in this assay, from the lowest: compounds 2, 4, 1 and 3 (each within the scatter of the next).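

At this place on the chain, nine bonds along from a sulfonyl sulfur, the swap of ethyl for hydroxy is the first change shown that brings in a hydrogen-bond donor and a hydrogen-bond acceptor, and in this assay it gives a 1.5-fold lower number from compound 3 to compound 4 (0.18 log units; within the scatter) for that single swap. The steps of a 1.1-fold lower number from compound 1 to compound 4 (0.05 log units; within the scatter) and a 1.1-fold higher number from compound 2 to compound 4 (0.04 log units; within the scatter) also stay inside the scatter, so compound 4, with its hydroxy, does not separate from any of the three compounds whose chains hold only carbon, and this assay therefore reads the loss of ethyl and the arrival of hydroxy as no measurable change. No measured information is available that would tie this result to any property of the hydroxy group.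

The compounds shown carry hydroxy at this one place only, so it remains open whether the same result would hold for hydroxy elsewhere on the chain or on a longer chain. As far as these compounds go, it also remains open whether an amine or a carboxylic acid at this place would stay within the scatter of compound 4 or move clear of it.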